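Phenyl for Methyl: Estimating the Fourth Compound

A few compounds are considered here, and "the series" means these few. Any claim that something is new, unique, unknown or untested is made for them only; others in the source may bear on it.

Measured so far:
Compound 1 `C=C(C)C(=O)c1ccc(OCc2nc(C)no2)c(C)c1C` gives 3200 nM in a functional assay on HL-60 cells (Homo sapiens) for inhibition; on this read-out lower numbers stand for stronger inhibition of growth and higher numbers for weaker inhibition of growth.
Compound 2 `C=C(C)C(=O)c1ccc(OCc2nc(-c3ccccc3)no2)c(C)c1C` gives 3500 nM.
Compound 3 `C=C(CC)C(=O)c1ccc(OCc2nc(C)no2)c(Cl)c1Cl` gives 2300 nM.

Compound 2 differs from compound 1 by phenyl in place of methyl on an aromatic carbon. That change gave a 1.1-fold higher number from compound 1 to compound 2 (0.04 log units; within the scatter). Compound 4 `C=C(CC)C(=O)c1ccc(OCc2nc(-c3ccccc3)no2)c(Cl)c1Cl` differs from compound 3 by phenyl in place of methyl on an aromatic carbon, the same change made on the core of compound 3. How the core of compound 3 differs from the core of compound 1 is not broken down here; the two measured values of compound 1 and compound 3 lie within the scatter of each other.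

For compound 4 a step of a 1.1-fold higher number from compound 3 to compound 4 (0.04 log units; within the scatter) is expected, because a 1.1-fold higher number from compound 1 to compound 2 (0.04 log units; within the scatter) shows this change leaving the number essentially unmoved on the core of compound 1. Compound 4 is estimated at 2500 nM, with a range from 1200 nM to 5500 nM.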

Compound 4, concentration for 50% growth inhibition: 1700 nM
Compound 4: middle estimate off by 1.5-fold (0.17 log units), on the high side; the measured number falls inside the stated range.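

In this assay, phenyl in place of methyl on an aromatic carbon gives a 1.4-fold lower number from compound 3 to compound 4 (0.13 log units; within the scatter). Set beside the earlier step, the change carries over from one core to the other with no difference that stands out from the scatter: the same change on two cores in this assay, a 1.1-fold higher number (0.04 log units; within the scatter) from compound 1 to compound 2 and a 1.4-fold lower number (0.13 log units; within the scatter) from compound 3 to compound 4, 1.5-fold (0.17 log units) apart, within the scatter of two such steps. This shows that the swap leaves the number essentially unmoved on these two cores, but it does not show the same for any other core, and two pairs cannot reveal a small real difference between cores.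

The compounds shown leave open what other groups at this aromatic carbon, such as an amine, a carboxylic acid or a longer chain, would do. They also do not separate the individual places in which the core of compound 3 differs from the core of compound 1.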